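From 4-methylthiophen-2-yl to pyridin-3-yl on the shared core

The source may hold more compounds than are shown below. What is called first, only, known or untested is meant among the compounds shown, and "the series" means these compounds.

Of the compounds shown here, two with a shared core have been measured in an ADME assay (liver) for metabolic stability, with Liver microsome (Rattus norvegicus) as the target, using microsomes and NADPH, with a stated time of 30 min, tested at 1 uM; on this read-out lower numbers stand for slow clearance and higher numbers for fast clearance. Compound 1 `CC(C)(O)C#Cc1cc(C(O)(C(F)(F)F)C(F)(F)F)cnc1N1CCN(S(=O)(=O)c2ccc(N)nc2)CC1` gives 16 mL.min-1.g-1, while compound 2 `Cc1csc(-c2cc(C(O)(C(F)(F)F)C(F)(F)F)cnc2N2CCN(S(=O)(=O)c3ccc(N)nc3)CC2)c1` gives 399 mL.min-1.g-1, the higher of the two numbers and thus the faster clearance. Compound 3 `Nc1ccc(S(=O)(=O)N2CCN(c3ncc(C(O)(C(F)(F)F)C(F)(F)F)cc3-c3cccnc3)CC2)cn1` keeps the core and carries pyridin-3-yl in place of 4-methylthiophen-2-yl on an aromatic carbon. Among the compounds with values here, only one measured step bears on this change. That step, a 25-fold higher number from compound 1 to compound 2 (1.40 log units; beyond the scatter), is large, lies beyond the scatter and falls on the same aromatic carbon, so the group at this place can move the number widely. Within the data shown here, it involves a different departing group, however, and no measured pair tests pyridin-3-yl directly. With compound 2 at the top of the range seen so far, at 399 mL.min-1.g-1, a fall is expected, though a smaller one than the measured step. The change expected here is estimated as a 4.4-fold lower number from compound 2 to compound 3 (0.65 log units; beyond the scatter). For compound 3 the estimated value in this assay is 90 mL.min-1.g-1, with an expected range from 25 mL.min-1.g-1 to 300 mL.min-1.g-1.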

Compound 3, intrinsic clearance in microsomes: 20 mL.min-1.g-1
For compound 3 the middle estimate is 4.5-fold (0.65 log units) above the measured one; the measured number lies below the stated range.
By their numbers in this assay, from the lowest: compounds 1 and 3 (each within the scatter of the next); then compound 2.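

In this assay, putting pyridin-3-yl in place of 4-methylthiophen-2-yl on this aromatic carbon gives a 20-fold lower number from compound 2 to compound 3 (1.30 log units; beyond the scatter), which shows that the number can swing widely between two aromatic rings with the same count of heavy atoms, hydrogen-bond donors and acceptors. The earlier step could not show this, as it compared 4-methylthiophen-2-yl with the quite different 3-hydroxy-3-methylbut-1-yn-1-yl. The new comparison with that alkynyl group gives a 1.3-fold higher number from compound 1 to compound 3 (0.10 log units; within the scatter), so an aromatic ring at this place does not by itself bring a high number, and among these three compounds only compound 2 stands apart. No measurement available here accounts for the gap between the two rings.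

The compounds shown leave open whether the high number of compound 2 goes with the sulfur-bearing ring or with its methyl group, a question that an unsubstituted thiophen-2-yl group would help to settle. On these data alone, it also remains open how a plain phenyl ring, or a pyridin-3-yl ring carrying a methyl group, would read on this carbon.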